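Small Phenols Tested Against a Tyrosine Phosphatase

The compounds below may be only part of what the source reports. "The series", "measured", "known", "first", "only" and "open" are said of these compounds alone.

Compound 1 `Oc1ccc(-c2ccccc2)cc1C(O)(C(F)(F)F)C(F)(F)F` was examined in an assay on isolated protein for inhibition of tyrosine-protein phosphatase non-receptor type 13 (Homo sapiens), read by spectrophotometry; a lower number here means a stronger inhibitor, a higher number a weaker inhibitor. In this assay compound 1 gives > 500000 nM, which is a limit of the assay rather than a measured number. Compound 2 `O=C(COc1ccc2cc(C(O)(C(F)(F)F)C(F)(F)F)c(O)cc2c1)NC1CC1`, carrying a larger fused core with an amide-bearing side chain, was run in the same way. In this assay compound 2 gives > 20000 nM, again a limit and not a number. Where compound 1 stands among the values shown is therefore only loosely fixed: its own value is a limit, (the limit of > 500000 nM in this assay, at which 1 of the 2 values shown sits), and the one further value shown is also a limit, (the limit of > 20000 nM in this assay, at which 1 of the 2 values shown sits), so no ordering between the two compounds can be drawn. Within the data shown here, no step between measured compounds is available.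

Compound 3 `Cc1ccc(O)c(C(O)(C(F)(F)F)C(F)(F)F)c1` has not yet been measured. It differs from compound 1 in one place: methyl in place of phenyl on an aromatic carbon. Among the measured compounds shown here, with both known values being limits, there is no measured step to guide the size of this change. The step from compound 1 to compound 3 is expected to be a number no higher from compound 1 to compound 3 (the limit leaves the size open), that is, nothing beyond the scatter. Compound 3 is accordingly expected to give about 500000 nM in this assay, within a range from 100000 nM to 2000000 nM, and most probably as another limit rather than a number.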

Compound 3, half-maximal inhibitory concentration: 454000 nM
Estimate against measurement, compound 3: 1.1-fold (0.04 log units) above, within the range that was stated.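

In this assay compound 3 gives 454000 nM, the only value among those shown that is a number rather than a limit, so a methyl on this aromatic carbon, para to a hydroxy group, is enough for the small phenol to give a reading in the measurable range, with no phenyl and its six-membered aromatic ring of carbon only present. Exchanging the phenyl for the methyl gives an at least 1.1-fold lower number from compound 1 to compound 3 (0.04 log units; that floor lies within the scatter), which shows that the phenyl is not required for a reading at this level but does not show that the exchange moves the value beyond the scatter. The true size of the step stays open because the starting value is a limit, and a number for compound 1 would be needed to fix it: the limit of > 500000 nM in this assay, at which 1 of the 3 values shown sits.

Compound 2 gives > 20000 nM, which is a limit, and it differs from compound 3 in more than one place, so it adds nothing about this position. On these data alone, what an amine, a carboxylic acid or a longer chain on this same aromatic carbon would give remains open, as does whether any group here can bring the value far lower.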